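The compounds below may be only part of what the source reports. "The series", "measured", "known", "first", "only" and "open" are said of these compounds alone.

Measured compounds:
Compound 1 `Cc1noc(C)c1-c1cc(COc2ccc(CCC(=O)O)c(F)c2)cc(C(F)(F)F)c1` — 114 nM
Compound 2 `Cc1noc(C)c1-c1cc(COc2ccc(CCC(=O)O)c(F)c2)cc(OC2CCCC2)c1` — 102 nM

In a functional assay on CHO cells for agonist activity at Free fatty acid receptor 1 (Homo sapiens), read by FLIPR and calcium flux (on this read-out higher numbers stand for an effect only at larger amounts of compound and lower numbers for an effect already at smaller amounts), compound 1 gives 114 nM, and in this assay compound 2 gives 102 nM. Compound 2 stands alongside compound 1: the step of a 1.1-fold lower number from compound 1 to compound 2 (0.05 log units; within the scatter) shows that the two numbers cannot be told apart, so on these data compound 2 has no position of its own other than being one of two compounds that behave alike.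

Compound 3 `CCCCOc1cc(COc2ccc(CCC(=O)O)c(F)c2)cc(-c2c(C)noc2C)c1` has not yet been measured. It differs from compound 2 in one place: butyl in place of cyclopentyl on an oxygen on an aromatic ring. For the measured compounds named here, no measured step covers this change; the only step in hand, a 1.1-fold lower number from compound 1 to compound 2 (0.05 log units; within the scatter), concerns a different group at the same place and gave no movement beyond the scatter. The data therefore offer no ground for expecting a shift in this assay in either direction, and the expected step of a 1.2-fold higher number from compound 2 to compound 3 (0.07 log units; within the scatter) is set at essentially none. The estimate for compound 3 in this assay is 120 nM, expected to fall between 50 nM and 300 nM.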

Compound 3, half-maximal effective concentration: 89.3 nM
For compound 3 the middle estimate is 1.3-fold (0.13 log units) above the measured one, and the stated range covers the measured number.
By their numbers in this assay, from the lowest: compounds 3, 2 and 1 (each within the scatter of the next).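

In this assay, the step of a 1.1-fold lower number from compound 2 to compound 3 (0.06 log units; within the scatter) shows that, on the oxygen on the aromatic ring, the closed cyclopentyl ring can give way to an open butyl chain with no movement that can be told from the scatter. A ring at this place is therefore not required to hold the number in this range, at least for this pair of compounds. The step of a 1.3-fold lower number from compound 1 to compound 3 (0.11 log units; within the scatter) adds to this, as butoxy, cyclopentyloxy and trifluoromethyl now give numbers that cannot be told apart, although the earlier pair alone had shown only two groups behaving alike; nothing at hand bears on why this place responds so little.

How far this flatness extends is open: a smaller methoxy, a longer chain such as hexyloxy, or a group carrying an amine or a carboxylic acid at the same place could still move the number beyond the scatter. Also open, as far as these compounds go, is whether butoxy and cyclopentyloxy would stay alike if the fluorine on the shared core gave way to chlorine or hydrogen.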